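The source may hold more compounds than are shown below. What is called first, only, known or untested is meant among the compounds shown, and "the series" means these compounds.

Measured so far:
- compound 1 `COc1ccc(-c2csc(NC(=O)c3ccc([N+](=O)[O-])o3)n2)cc1`: 63000 nM
- compound 2 `O=C(Nc1nc(-c2cccc(F)c2)cs1)c1ccc([N+](=O)[O-])o1`: 51600 nM

In an ADME assay on Vero cells (Chlorocebus sabaeus) for cytotoxicity, read by MTT assay, with a stated time of 72 h (on this read-out higher numbers stand for weaker inhibition and lower numbers for stronger inhibition), compound 1 gives 63000 nM. Compound 2 gives 51600 nM in this assay. For the measured compounds named here, the two numbers sit close together: the single step seen so far, a 1.2-fold lower number from compound 1 to compound 2 (0.09 log units; within the scatter), lies within the scatter of repeated measurements, so no order between compound 2 and compound 1 can be read from these two values.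

Compound 3 `O=C(Nc1nc(-c2cccc(Cl)c2)cs1)c1ccc([N+](=O)[O-])o1` differs from compound 2 in one place: chloro in place of fluoro on an aromatic carbon. Going by the values given here, only one measured step bears on a change at this position of the shared core, the exchange from compound 1 to compound 2, and that step, a 1.2-fold lower number from compound 1 to compound 2 (0.09 log units; within the scatter), was within the scatter. Nothing else in the data points toward a move in either direction, so for compound 3 a step no larger than the scatter is expected, a 1.0-fold lower number from compound 2 to compound 3 (0.01 log units; within the scatter). The estimate for compound 3 in this assay is 50000 nM, expected to fall between 25000 nM and 100000 nM.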

Compound 3, half-maximal inhibitory concentration: 43700 nM
Estimate against measurement, compound 3: 1.1-fold (0.06 log units) above; the measured number falls inside the stated range.
By their numbers in this assay, from the lowest: compounds 3, 2 and 1 (each within the scatter of the next).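

In this assay the exchange of chloro for fluoro on an aromatic carbon, meta to a large group, gives (a 1.2-fold lower number from compound 2 to compound 3 (0.07 log units; within the scatter)), so replacing one halogen with another at this position leaves the two compounds indistinguishable on this read-out. The wider exchange of 4-methoxyphenyl for 3-chlorophenyl gives (a 1.4-fold lower number from compound 1 to compound 3 (0.16 log units; within the scatter)), so even this change, which differs in both the substituent and its place on the ring, stays inside the usual variation between repeat measurements, and the three compounds cannot be put in any order. No supporting data explain why these numbers sit so close together.

What remains open is whether any group at this position can move the number beyond the scatter, since a methoxy group, fluoro and chloro are the only substituents shown on this ring. An amine or a carboxylic acid there, or a longer chain in place of the phenyl ring, would test whether this flat picture holds beyond these three compounds.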